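A few compounds are considered here, and "the series" means these few. Any claim that something is new, unique, unknown or untested is made for them only; others in the source may bear on it.

Measured compounds:
- compound 1 `COc1ccc(OC)c(/C=N/NC(=O)Nc2ccc(Oc3ccnc(-c4nncn4CCN(C)C)c3)c(F)c2)c1` — 2930 nM
- compound 2 `CN(C)CCn1cnnc1-c1cc(Oc2ccc(NC(=O)N/N=C/c3ccccc3O[N+](=O)[O-])cc2F)ccn1` — 1270 nM

In a functional assay on NCI-H460 cells (Homo sapiens) for cytotoxicity, read by MTT assay, with a stated time of 72 h (a lower number here means a stronger inhibitor, a higher number a weaker inhibitor), compound 1 gives 2930 nM, the highest of the two numbers; compound 2 comes nearest, and the step of a 2.3-fold lower number from compound 1 to compound 2 (0.36 log units; beyond the scatter) is modest but beyond the scatter.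

Compound 3 `CN(C)CCn1cnnc1-c1cc(Oc2ccc(NC(=O)N/N=C/c3ccccc3)cc2F)ccn1` is not yet measured. It differs from compound 1 in one place: phenyl in place of 2,5-dimethoxyphenyl on a carbon with a double bond to nitrogen. Within the data shown here, the one measured step that bears on this is the change from compound 1 to compound 2, where another group replaced the same 2,5-dimethoxyphenyl on the carbon with a double bond to nitrogen and the number fell by a 2.3-fold lower number from compound 1 to compound 2 (0.36 log units; beyond the scatter). Among the measured compounds shown here, that step shows the shared core tolerates exchange at this position, but no measured compound carries a plain phenyl there, so the direction for compound 3 rests on weak ground. Compound 3 is expected to land near compound 1, with at most a modest move, so the estimated step is a 1.3-fold lower number from compound 1 to compound 3 (0.12 log units; within the scatter). Compound 3 is therefore estimated at 2200 nM, within a range of 800 nM to 6000 nM.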

Compound 3, half-maximal inhibitory concentration: 1780 nM
The estimate for compound 3 lay 1.2-fold (0.09 log units) above the measured number, and the stated range covers the measured number.
By their numbers in this assay, from the lowest: compounds 2, 3 and 1 (each within the scatter of the next, the first and the last beyond it).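

In this assay the swap of 2,5-dimethoxyphenyl for plain phenyl on the carbon with a double bond to nitrogen gives a 1.6-fold lower number from compound 1 to compound 3 (0.22 log units; within the scatter) and thus shows that this position holds its number without either methoxy group, a point the earlier pair could not settle. Hydrogen in place of nitrooxy on an aromatic carbon gives a 1.4-fold higher number from compound 2 to compound 3 (0.15 log units; within the scatter) and so the nitrooxy group cannot be told apart from plain hydrogen here, even though the earlier step between the two substituted compounds lay beyond the scatter; that step now reads as the sum of two smaller differences, neither clear of the scatter alone. Nothing shown here explains these numbers, and no independent data bear on the result.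

The compounds shown leave open whether a phenyl carrying an amine or a carboxylic acid on this carbon would move the number clearly away from that of compound 3. They also leave open whether a saturated ring such as cyclohexyl, or a longer chain in place of the aromatic ring, would keep the number in the same range.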